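This account rests on a few compounds, and the source may have more. Where it says the series, first, only, none or still open, it means among the compounds named here.

Measured in a functional assay on MCF7 cells (Homo sapiens) for antiproliferative activity; a lower number here means a stronger inhibitor, a higher number a weaker inhibitor:
- compound 1 `O=C(Nc1ccc(O)c2c(=O)cc(-c3ccccc3Cl)oc12)c1ccc(Cl)cc1`: 4600 nM
- compound 2 `O=C(Nc1c(O)cc(O)c2c(=O)cc(-c3ccccc3Cl)oc12)c1ccccc1`: 8500 nM
- compound 3 `CSCC[C@@H](NC(=O)OC(C)(C)C)C(=O)Nc1ccc(O)c2c(=O)cc(-c3ccccc3Cl)oc12`: 2800 nM

Compound 1 holds the second highest of these three numbers, and it lies within the scatter of both compound 2 and compound 3. Compound 4 `C[C@H](NC(=O)OC(C)(C)C)C(=O)Nc1ccc(O)c2c(=O)cc(-c3ccccc3Cl)oc12` has not been measured. It carries 1-((tert-butoxycarbonyl)amino)ethyl in place of 4-chlorophenyl on a carbonyl carbon of compound 1: 1-((tert-butoxycarbonyl)amino)ethyl in place of 4-chlorophenyl on a carbonyl carbon. Within the data shown here, no measured pair differs in one place only, so the expectation rests on thin evidence. With compound 1 at 4600 nM and compound 3 at 2800 nM, no step beyond the scatter is expected in this assay. The expected change is a 1.3-fold lower number from compound 1 to compound 4 (0.12 log units; within the scatter). For compound 4 the estimated value is 3500 nM, with an expected range of 1500 nM to 8500 nM.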

Compound 4, half-maximal inhibitory concentration: 5500 nM
The estimate for compound 4 lay 1.6-fold (0.20 log units) below the measured number, within the range that was stated.
By their numbers in this assay, from the lowest: compounds 3, 1, 4 and 2 (each within the scatter of the next, the first and the last beyond it).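

Swapping 4-chlorophenyl for 1-((tert-butoxycarbonyl)amino)ethyl on a carbonyl carbon gives a 1.2-fold higher number from compound 1 to compound 4 (0.08 log units; within the scatter) in this assay and so shows, in the first single-place comparison here, that an aromatic ring of carbon only can be replaced by a group with no ring without moving the number beyond the scatter. No measurement shown explains this result. Still open, from the compounds shown here alone, is whether an amine or a carboxylic acid in this place would shift the number beyond the scatter, in either direction.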